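Trimming a Benzofuran to a Furan on a Nucleoside Core

The source may report more compounds than this note shows. Statements on the series, on what has been measured and on what is new or still open speak of the compounds shown alone.

Compound 1 `COc1ncnc2c1c(I)cn2[C@@H]1O[C@H](CO)[C@@H](O)[C@H]1O`: 14800 nM
Compound 2 `O=c1[nH]cnc2c1c(-c1cc3ccccc3o1)cn2[C@@H]1O[C@H](CO)[C@@H](O)[C@H]1O`: > 20000 nM
Compound 3 `Cc1ncnc2c1c(-c1ccoc1)cn2[C@@H]1O[C@H](CO)[C@@H](O)[C@H]1O`: > 20000 nM

All three were tested in a functional assay on K562 cells (Homo sapiens), read by MTT assay, with a stated time of 72 h; a lower number here means a stronger inhibitor, a higher number a weaker inhibitor. Compound 1 gives a measured number, 14800 nM. For compound 2 the result is not a number but a limit, > 20000 nM. Compound 3 likewise returns only a limit, > 20000 nM. Compound 2 therefore stands at the limit of > 20000 nM in this assay, at which 2 of the 3 values shown sit, with no measured figure of its own to compare against compound 1.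

Compound 4 `O=c1[nH]cnc2c1c(-c1ccco1)cn2[C@@H]1O[C@H](CO)[C@@H](O)[C@H]1O` keeps the shared core of compound 2 and changes one group: furan-2-yl in place of 1-benzofuran-2-yl on an aromatic carbon. The change removes one six-membered aromatic ring of carbon only and leaves a single five-membered aromatic ring with one hetero atom in its place.

No measured step of this kind is available among these compounds, so the size of the step must be guessed. Since compound 2 sits at the limit of > 20000 nM in this assay, at which 2 of the 3 values shown sit, a small step in either direction could remain hidden behind the limit. Compound 4 is expected to stay weak, with the step that the limit leaves unreadable from compound 2 to compound 4 expected to be small. The estimate for compound 4 is 25000 nM, in a range from 8000 nM to 80000 nM.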

Compound 4, half-maximal inhibitory concentration: 17800 nM
Compound 4: middle estimate off by 1.4-fold (0.15 log units), on the high side; measured number inside the range.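

Removing the six-membered aromatic ring of carbon only from the 1-benzofuran-2-yl group gives a result that can be read as a number: in this assay compound 4 gives 17800 nM, the first measured figure for the core it shares with compound 2. The change amounts to an at least 1.1-fold lower number from compound 2 to compound 4 (0.05 log units; that floor lies within the scatter), so only a floor for the step is known, and that floor does not show that removing this ring changes the result. Compound 2 itself gives a limit and not a number: the limit of > 20000 nM in this assay, at which 2 of the 4 values shown sit.

The compounds shown leave open how an amine, a carboxylic acid or a phenyl ring on this aromatic carbon would read in this assay. They also leave open whether furan-3-yl in place of furan-2-yl on the core of compound 4 would change the result.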